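Acetylthiophenyl for Acetamidophenyl: Cytotoxicity Outlook

The source may report more compounds than this note shows. Statements on the series, on what has been measured and on what is new or still open speak of the compounds shown alone.

The read-out here is an ADME assay on HEK293 cells (Homo sapiens) for cytotoxicity, read by CellTiter-Glo and resazurin assay, with a stated time of 72 h; on this read-out higher numbers stand for an effect only at larger amounts of compound and lower numbers for an effect already at smaller amounts. Compound 1 `CC(=O)Nc1cccc(-c2ccc(C(=O)N(Cc3cccc(OCCCCCC(=O)O)c3)C(C)C)cc2)c1` reaches only a limit of this assay, > 26000 nM. Compound 2 `CCOC(=O)CCCCCOc1cccc(CN(C(=O)c2ccc(-c3cccc(NC(C)=O)c3)cc2)C(C)C)c1` likewise reaches only a limit of this assay, > 26000 nM. Compound 3 `CCOC(=O)CCCCCOc1cccc(CN(C(=O)c2ccc(-c3cccc(Oc4ccccc4)c3)cc2)C(C)C)c1` also reaches only a limit of this assay, > 19600 nM. The two measured steps are therefore unreadable: a step that the two limits leave unreadable from compound 1 to compound 2 cannot be sized, and a step that the two limits leave unreadable from compound 2 to compound 3 cannot be sized either. Compound 2 thus stands where every measured compound stands, at a limit, as the limit of > 26000 nM in this assay, at which 2 of the 3 values shown sit, and the limit of > 19600 nM in this assay, at which 1 of the 3 values shown sits, show.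

Compound 4 `CCOC(=O)CCCCCOc1cccc(CN(C(=O)c2ccc(-c3ccc(C(C)=O)s3)cc2)C(C)C)c1` differs from compound 2 by 5-acetylthiophen-2-yl in place of 3-acetamidophenyl on an aromatic carbon. Going by the values given here, no measured step bears directly on this change, and the two that exist carry no readable size. With every shown value a limit, the step from compound 2 to compound 4 is expected to be a step that the limit leaves unreadable from compound 2 to compound 4, which is no change beyond the scatter. The estimate for compound 4 is 30000 nM, within 12000 nM to 100000 nM, most likely again reported as a limit.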

Compound 4, half-maximal effective concentration: > 26000 nM
Compound 4: only a limit was reported; the forecaster's own chance of this, stated with the estimate: 85%; the middle value lies beyond the limit too.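

Going by these compounds alone, compound 2 and compound 4 each reach only a limit, so putting 5-acetylthiophen-2-yl in place of 3-acetamidophenyl gives no step that can be read. The compounds shown leave open at what concentration any of them would harm these cells.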